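Working notes: compound 3, the aryl swap on compound 1

A few compounds are considered here, and "the series" means these few. Any claim that something is new, unique, unknown or untested is made for them only; others in the source may bear on it.

Among the compounds with values here, compound 1 `COc1ccccc1-c1nnc(-c2ccc(C(=O)N/N=C/c3cc(O)ccc3O)cc2)o1` is the stronger of the two compounds measured so far in an ADME assay on THP-1 cells (Homo sapiens) for cytotoxicity; a higher number here means a weaker inhibitor, a lower number a stronger inhibitor: compound 1 gives 100000 nM, the lowest of the two numbers. Compound 2 `COc1ccccc1-c1nnc(-c2ccc(C(=O)N/N=C/c3cccc(F)c3)cc2)o1` gives 353000 nM in this assay. Within the data shown here, the single step between them, a 3.5-fold higher number from compound 1 to compound 2 (0.55 log units; beyond the scatter), goes with 3-fluorophenyl in place of 2,5-dihydroxyphenyl on a carbon with a double bond to nitrogen.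

Compound 3 `COc1ccccc1-c1nnc(-c2ccc(C(=O)N/N=C/c3cccc([N+](=O)[O-])c3)cc2)o1` has not been measured. It differs from compound 1 by 3-nitrophenyl in place of 2,5-dihydroxyphenyl on a carbon with a double bond to nitrogen. Among the measured compounds shown here, only the step from compound 1 to compound 2 bears on this change: there the same 2,5-dihydroxyphenyl left the same place, a differently substituted phenyl entered, and the number rose beyond the scatter. A step of similar direction and modest size, towards a higher number, is therefore expected for compound 3, a 2.5-fold higher number from compound 1 to compound 3 (0.40 log units; beyond the scatter). Compound 3 is estimated at 250000 nM in this assay, with a range from 80000 nM to 800000 nM.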

Compound 3, half-maximal inhibitory concentration: 119000 nM
Beside the measured number, compound 3's estimate is 2.1-fold (0.32 log units) above it; the range from low to high includes it.
By their numbers in this assay, from the lowest: compounds 1 and 3 (each within the scatter of the next); then compound 2.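

In this assay the place on a carbon with a double bond to nitrogen tolerates loss of the 2,5-dihydroxyphenyl without any readable shift when 3-nitrophenyl enters, with a 1.2-fold higher number from compound 1 to compound 3 (0.08 log units; within the scatter) as the step, so the rise seen with 3-fluorophenyl does not hold for every replacement, and the 0 hydrogen-bond donors of 3-nitrophenyl against the 2 of 2,5-dihydroxyphenyl go with no change beyond the scatter. With the aryl ring otherwise alike, a 3.0-fold lower number from compound 2 to compound 3 (0.47 log units; beyond the scatter) for nitro in place of fluoro shows that the substituent on an aromatic carbon alone moves the number. No measurement at hand explains either step.

As far as these compounds go, whether an amine or a carboxylic acid on this phenyl would give a number like that of compound 3 or like that of compound 2 remains open. Also open, from the compounds shown here alone, is how a longer alkyl chain in place of the whole aryl group would read.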